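The compounds below may be only part of what the source reports. "The series", "measured", "known", "first", "only" and "open" are said of these compounds alone.

In an assay on isolated protein for inhibition of Amine oxidase [flavin-containing] A (Homo sapiens), read by fluorescence and Amplex Red, with a stated time of 15 min, tested at 50 uM (on this read-out lower numbers stand for less inhibition and higher numbers for more inhibition at the one concentration tested (going by the name of the read-out)), compound 1 `C#CCN(CC)Cc1cn(-c2cc(NC(=S)NCC)ncn2)cn1` gives 6.71%. Compound 2 `C#CCN(CCCC)Cc1cn(-c2cc(NC(=S)NCC)ncn2)cn1` gives 2.43%, and compound 3 `C#CCN(Cc1cn(-c2cc(NC(=S)NCC)ncn2)cn1)C(C)=O` gives 4.83%. Compound 3 stands second highest of the three numbers, with compound 1 its nearest neighbour and compound 2 its furthest, both within the scatter. Compound 4 `C#CCN(Cc1ccccc1)Cc1cn(-c2cc(NC(=S)NCC)ncn2)cn1` differs from compound 3 by benzyl in place of acetyl on an amine nitrogen. Two measured steps alter the same amine nitrogen: a number 1.9 percentage points lower from compound 1 to compound 3 (within the scatter) and a number 2.4 percentage points higher from compound 2 to compound 3 (within the scatter). Neither moves this assay beyond the scatter, so no step beyond the scatter is expected here either. The step is therefore expected to be a number 0.2 percentage points higher from compound 3 to compound 4 (within the scatter). For compound 4 the estimate in this assay is 5%, with a range from -2% to 16%.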

Compound 4, a percentage reported as inhibition, at one concentration (the size of the read-out at that concentration, not a potency): 17.8%
Compound 4: the middle estimate sits 12.8 percentage points below what was measured, and the stated range ends below it.
By their numbers in this assay, from the lowest: compounds 2, 3 and 1 (each within the scatter of the next); then compound 4.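

In this assay the amine nitrogen can move the number beyond the scatter, which ethyl, butyl and acetyl there did not show: benzyl gives a number 13 percentage points higher from compound 3 to compound 4 (beyond the scatter) and also a number 15.4 percentage points higher from compound 2 to compound 4 (beyond the scatter) and a number 11.1 percentage points higher from compound 1 to compound 4 (beyond the scatter) on the same nitrogen. All three steps are modest, and compound 4 alone, the only one here with a six-membered aromatic ring at this place, stands apart from the others. Nothing available accounts for this rise. Going by these compounds, whether the aromatic ring itself matters stays open, since a cyclohexylmethyl or phenethyl group on this nitrogen would be needed to tell.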